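The source may report more compounds than this note shows. Statements on the series, on what has been measured and on what is new or still open speak of the compounds shown alone.

Compound 2 `CC(C)Oc1ccc(C(=O)Nc2ccc(CN3CCN(C)CC3)c(C(F)(F)F)c2)cc1[N+](=O)[O-]` stands lowest of the two values measured in a toxicity assay on Huh-7.5 cells (Homo sapiens) for inhibition, read by MTT assay, with a stated time of 96 h; a higher number here means that more compound is tolerated, a lower number that less compound is tolerated: compound 2 gives 3500 nM, while compound 1 `CCC(=O)Nc1cc(C(=O)Nc2ccc(CN3CCN(C)CC3)c(C(F)(F)F)c2)ccc1OCCCCl` gives 7870 nM, a gap beyond the usual scatter. Compound 3 `CCC(=O)Nc1cc(C(=O)Nc2ccc(CN3CCN(C)CC3)c(C(F)(F)F)c2)ccc1OC(C)C` has not yet been measured. It differs from compound 2 in one place: propanoylamino in place of nitro on an aromatic carbon. Compound 3 thus carries the same propanoylamino group as compound 1, so an upward step is expected a 1.7-fold higher number from compound 2 to compound 3 (0.23 log units; within the scatter), although compound 1 and compound 2 also differ elsewhere, which leaves its size uncertain. Compound 3 is expected to give 6000 nM in this assay, within 2500 nM to 15000 nM.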

Compound 3, half-maximal cytotoxic concentration: 15300 nM
Compound 3: the middle estimate sits 2.6-fold (0.41 log units) below what was measured, and the stated range ends below it.
By their numbers in this assay, from the lowest: compound 2; then compounds 1 and 3 (each within the scatter of the next).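

In this assay, propanoylamino in place of nitro on the aromatic carbon ortho to an isopropoxy group gives a 4.4-fold higher number from compound 2 to compound 3 (0.64 log units; beyond the scatter) and shows that this single change alone shifts how much compound the cells tolerate. Isopropyl in place of 3-chloropropyl on the oxygen gives a 1.9-fold higher number from compound 1 to compound 3 (0.29 log units; within the scatter) and so shows no clear shift. No measurement here explains why the first change matters. As far as these compounds go, whether an amine or a carboxylic acid on that aromatic carbon would raise the number further remains open.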